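The compounds below may be only part of what the source reports. "The series", "measured", "known", "first", "only" and "open" are said of these compounds alone.

Among the measured compounds shown here, compound 3 `CCc1cc(C(C)=O)c(O)cc1OCCCCCCC(=O)O` gives 38% in an assay on isolated protein for binding affinity to leukotriene B4 receptor 1 (Homo sapiens), tested at 1 uM (on this read-out higher numbers stand for more inhibition at the one concentration tested (going by the name of the read-out) and lower numbers for less inhibition), the largest of the three numbers so far; the step of a number 24 percentage points higher from compound 2 to compound 3 (beyond the scatter) lies beyond the scatter, whereas a number 8 percentage points higher from compound 1 to compound 3 (within the scatter) does not. Compound 1 `CCc1cc(C(C)=O)c(O)cc1OCCCCCCC(C)(C)C#N` gives 30% and compound 2 `CCc1cc(C(C)=O)c(O)cc1OCCCCCCSC` gives 14%. Compound 4 `CCc1cc(C(C)=O)c(O)cc1OCCCCCCC(=O)Nc1nn[nH]n1` alters the chain end: (2H-tetrazol-5-yl)amino in place of hydroxy on a carbonyl carbon. For the measured compounds named here, no measured step replaces the hydroxy of the carboxy terminus, so the only guide is that tail variation moved this assay by a number 16 percentage points lower from compound 1 to compound 2 (beyond the scatter) and a number 24 percentage points higher from compound 2 to compound 3 (beyond the scatter), both modest, with compound 3 at the upper end. A step of a number 7 percentage points higher from compound 3 to compound 4 (within the scatter) is therefore expected, a small rise not securely beyond the scatter. Compound 4 is estimated at 45%, with a range from 20% to 70%.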

Compound 4, a percentage reported as inhibition, at one concentration (the size of the read-out at that concentration, not a potency): 83%
For compound 4 the middle estimate is 38 percentage points below the measured one, and the stated range ends below it.
By their numbers in this assay, from the lowest: compound 2; then compounds 1 and 3 (each within the scatter of the next); then compound 4.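

In this assay, among the compounds shown here, (2H-tetrazol-5-yl)amino in place of hydroxy on a carbonyl carbon gives a number 45 percentage points higher from compound 3 to compound 4 (beyond the scatter) and is the first large step at the chain end, where earlier steps were modest at most. The (2H-tetrazol-5-yl)carbamoyl end also gives a number 69 percentage points higher from compound 2 to compound 4 (beyond the scatter) and a number 53 percentage points higher from compound 1 to compound 4 (beyond the scatter) so compound 4 stands clear of all three earlier compounds. No available data explain this rise.

Still open, from the compounds shown here alone, is whether a plain carboxamide or a triazolylamino group on the same carbonyl carbon would give a similar number. Also open, going by these compounds, is how a shorter or longer chain would behave with the (2H-tetrazol-5-yl)carbamoyl end.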